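Furan-2-yl in Place of Pyridin-3-yl on the Shared Core

The source may hold more compounds than are shown below. What is called first, only, known or untested is meant among the compounds shown, and "the series" means these compounds.

Measured so far in an assay on cells for inhibition of high affinity 3',5'-cyclic-AMP phosphodiesterase 7A (Homo sapiens), read by scintillation counting and cAMP accumulation, with a stated time of 30 min; a higher number here means a weaker inhibitor, a lower number a stronger inhibitor: compound 1 `CCn1c(NC(C)C)nc2c(-c3cncnc3)csc2c1=O` gives 7.6 nM; compound 2 `CCn1c(NC(C)C)nc2c(-c3cccnc3)csc2c1=O` gives 4.4 nM; compound 3 `CCn1c(NC(C)C)nc2c(C3CCCN(C(C)=O)C3)csc2c1=O` gives 5.1 nM.

Of the three numbers, that of compound 2 is the lowest, yet the step of a 1.7-fold lower number from compound 1 to compound 2 (0.24 log units; within the scatter) is within the scatter, and the value of compound 3 sits close to it. Compound 4 `CCn1c(NC(C)C)nc2c(-c3ccco3)csc2c1=O` differs from compound 2 by furan-2-yl in place of pyridin-3-yl on an aromatic carbon. Within the data shown here, the only measured step at this position is a 1.7-fold lower number from compound 1 to compound 2 (0.24 log units; within the scatter), a small one between two six-membered rings; no measured pair covers a five-membered ring here. Compound 4 is therefore expected to give a step of about a 1.4-fold higher number from compound 2 to compound 4 (0.13 log units; within the scatter), not beyond the scatter, so compound 4 is estimated at 6 nM with a range from 2.5 nM to 18 nM.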

Compound 4, half-maximal inhibitory concentration: 12 nM
Compound 4: middle estimate off by 2.0-fold (0.30 log units), on the low side; measured number inside the range.
By their numbers in this assay, from the lowest: compounds 2, 3, 1 and 4 (each within the scatter of the next, the first and the last beyond it).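

In this assay, among these compounds, furan-2-yl in place of pyridin-3-yl gives a 2.7-fold higher number from compound 2 to compound 4 (0.44 log units; beyond the scatter) and this is the only step at this position that lies beyond the scatter. Furan-2-yl in place of pyrimidin-5-yl gives a 1.6-fold higher number from compound 1 to compound 4 (0.20 log units; within the scatter) and so the five-membered ring stands apart from only one of the two six-membered rings. Nothing measured here explains the difference.

From the compounds shown here alone, whether a thiophene or a phenyl ring would fall with furan-2-yl or with pyridin-3-yl stays open. So does whether an amine or a carboxylic acid on the ring would move the number in either direction.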